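A few compounds are considered here, and "the series" means these few. Any claim that something is new, unique, unknown or untested is made for them only; others in the source may bear on it.

Measured in a functional assay on PC-3 cells (Homo sapiens) for inhibition, read by MTT assay, with a stated time of 72 h; a higher number here means a weaker inhibitor, a lower number a stronger inhibitor:
Compound 1 `CC(C)(C)OC(=O)N1CCN(C(=S)SCc2cn(-c3ccccc3F)nn2)CC1` — a limit only, > 128000 nM.
Compound 2 `O=C(OCc1ccccc1)N1CCN(C(=S)SCc2cn(Cc3ccc(F)cc3)nn2)CC1` — a limit only, > 128000 nM.
Compound 3 `COc1cc(Cn2cc(CSC(=S)N3CCNCC3)nn2)cc(OC)c1OC` — a limit only, > 128000 nM.

Within the data shown here, compound 2 stands nowhere on a scale: its value is a limit, as are the two others, so no compound can be set against another here. Compound 4 `O=C(OCc1ccccc1)N1CCN(C(=S)SCc2cn(Cc3ccc(Cl)cc3)nn2)CC1` differs from compound 2 by chloro in place of fluoro on an aromatic carbon. Among the measured compounds shown here, no measured pair differs in one place, so no step size is known; given the limit of > 128000 nM in this assay, at which 3 of the 3 values shown sit, the step from compound 2 to compound 4 is expected to show no change beyond the scatter, and a step that the limit leaves unreadable from compound 2 to compound 4 is the estimate. Compound 4 is expected to return a limit again, with an estimate of 200000 nM and a range from 100000 nM to 600000 nM.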

Compound 4, half-maximal inhibitory concentration: > 128000 nM
Compound 4 gave a limit, no number (the forecaster's own chance of this, stated with the estimate: 85%); the middle value is on the limit's open side.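

No step can be read from compound 2 to compound 4, chloro in place of fluoro on an aromatic carbon, because both results are limits: the limit of > 128000 nM in this assay, at which 4 of the 4 values shown sit.

The compounds shown leave open whether any change to this series gives a measurable value in this assay.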